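Methyl for hydrogen on the chain carbon: solubility notes

The source may hold more compounds than are shown below. What is called first, only, known or untested is meant among the compounds shown, and "the series" means these compounds.

Two compounds of the series carry numbers in a physicochemical assay for solubility, measured as kinetic solubility; on this read-out higher numbers stand for higher solubility and lower numbers for lower solubility. Compound 1, `CCC(=O)c1c[nH]c(C(=O)NC)c1`, gives 87 ug/mL in this assay. Compound 2, `CNC(=O)c1cc(C(=O)NC2CC2)n(Cc2ccccc2)n1`, reaches only a limit of the assay in this assay, reported as >= 155 ug/mL, so its solubility is known as a bound and not as a number. (the limit of >= 155 ug/mL in this assay, at which 1 of the 2 values shown sits). Among the compounds with values here, no step between two measured compounds is available, so the series itself gives no gauge of how a single small change moves the read-out.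

Compound 3, `CNC(=O)c1cc(C(=O)NC2CC2)n([C@@H](C)c2ccccc2)n1`, is the unmeasured analogue of compound 2. The change is methyl in place of hydrogen on a saturated chain carbon bound to an aromatic carbon and an aromatic nitrogen. Nothing measured here speaks to what this methyl does to solubility, and the limit on compound 2 leaves the starting point open. The step of an at least 1.2-fold lower number from compound 2 to compound 3 (0.11 log units; that floor lies within the scatter) is expected to be small, downward if anything, and not clearly beyond the scatter. Compound 3 is therefore estimated at 120 ug/mL in this assay, with a range from 45 ug/mL to 250 ug/mL, and with a real chance that the assay again returns only a limit.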

Compound 3, solubility: >= 165 ug/mL
Compound 3 gave a limit, no number (the forecaster's own chance of this, stated with the estimate: 40%); at least 1.3-fold (0.13 log units) between middle value and limit.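

In this assay compound 2 and compound 3 both return only limits of the assay and no numbers, so no step can be read between them. The compounds shown leave open what methyl in place of hydrogen on this saturated chain carbon does to the read-out.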